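This account rests on a few compounds, and the source may have more. Where it says the series, first, only, none or still open, it means among the compounds named here.

Measured in a functional assay on HeLa cells (Homo sapiens) for antiproliferative activity, read by MTT assay, with a stated time of 72 h; on this read-out lower numbers stand for stronger inhibition and higher numbers for weaker inhibition:
Compound 1 `COc1cc(C(=O)c2sc3ccccc3c2-c2ccc(C)cc2)cc(OC)c1OC`: 3700 nM
Compound 2 `COc1ccccc1-c1c(C(=O)c2cc(OC)c(OC)c(OC)c2)sc2ccccc12`: 5000 nM
Compound 3 `COc1ccc(OC)c(-c2c(C(=O)c3cc(OC)c(OC)c(OC)c3)sc3ccccc23)c1`: 10000 nM

The position of compound 3 is set by two steps: a 2.0-fold higher number from compound 2 to compound 3 (0.30 log units; within the scatter), and a 2.7-fold higher number from compound 1 to compound 3 (0.43 log units; beyond the scatter). Only the second lies beyond the scatter. Compound 4 `CCOc1ccc(-c2c(C(=O)c3cc(OC)c(OC)c(OC)c3)sc3ccccc23)cc1` carries 4-ethoxyphenyl in place of 2,5-dimethoxyphenyl on an aromatic carbon. The nearest measured comparison is compound 1, which also carries a group named with a 4-substituent, and the step to it is modest, a 2.7-fold higher number from compound 1 to compound 3 (0.43 log units; beyond the scatter). The step of a 1.4-fold higher number from compound 1 to compound 2 (0.13 log units; within the scatter) stays within the scatter. A modest move to a lower number is therefore expected in this assay, an estimated 2.2-fold lower number from compound 3 to compound 4 (0.35 log units; beyond the scatter). Compound 4 is estimated at 4500 nM, with an expected range of 1500 nM to 12000 nM.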

Compound 4, half-maximal inhibitory concentration: 3000 nM
Estimate against measurement, compound 4: 1.5-fold (0.18 log units) above; the range from low to high includes it.
By their numbers in this assay, from the lowest: compounds 4, 1, 2 and 3 (each within the scatter of the next, the first and the last beyond it).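

In this assay, 4-ethoxyphenyl in place of 2,5-dimethoxyphenyl at this position gives a 3.3-fold lower number from compound 3 to compound 4 (0.52 log units; beyond the scatter), so compound 3 stands apart from compound 4 as well as from compound 1, though not from compound 2. Ethoxy in place of methyl gives a 1.2-fold lower number from compound 1 to compound 4 (0.09 log units; within the scatter), so 4-ethoxyphenyl and 4-methylphenyl read alike here. The step of a 1.7-fold lower number from compound 2 to compound 4 (0.22 log units; within the scatter) likewise does not separate 4-ethoxyphenyl from 2-methoxyphenyl.

Going by these compounds, whether a longer chain such as butoxy, or an amine, would be accepted on this phenyl ring remains open. Nothing shown explains why these groups differ or read alike.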